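The source may report more compounds than this note shows. Statements on the series, on what has been measured and on what is new or still open speak of the compounds shown alone.

Measured so far:
compound 1 `CCOC(=O)c1sc(-c2cccc(NC(=O)c3ccccc3F)c2)nc1Nc1ccc(N2CCN(C)CC2)cc1` gives 96.4% in a functional assay on Ramos cells (Homo sapiens) for antiproliferative activity, read by CCK-8 assay, with a stated time of 72 h, tested at 40 uM; on this read-out lower numbers stand for less inhibition and higher numbers for more inhibition at the one concentration tested (going by the name of the read-out)
compound 2 `CN1CCN(c2ccc(Nc3nc(-c4cccc(NC(=O)c5cccc(F)c5)c4)sc3C(=O)O)cc2)CC1` gives 82.7% in this assay

Among the measured compounds shown here, of these two numbers, compound 2 stands lowest, and its only neighbour, compound 1, lies higher by a gap that is beyond the usual scatter of this assay. For the measured compounds named here, compound 1 and compound 2 differ in more than one place, so no single-change step between measured compounds is available to lean on.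

Compound 3 `CN1CCN(c2ccc(Nc3nc(-c4cccc(NC(=O)c5ccccc5F)c4)sc3C(=O)O)cc2)CC1` has not been measured yet. It differs from compound 2 in one place only: 2-fluorophenyl in place of 3-fluorophenyl on a carbonyl carbon. The two compounds hold the same atoms, joined differently, and the change sits on the carbonyl carbon of the amide.

Going by the values given here, with no measured step of this kind to guide it, only a modest move is expected here: the step from compound 2 to compound 3 in this assay is estimated as a number 2.3 percentage points higher from compound 2 to compound 3 (within the scatter), which would not be beyond the scatter. Compound 3 is therefore expected to give about 85% in this assay. For compound 3 the estimate is expected to fall between 70% and 96%.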

Compound 3, a percentage reported as inhibition, at one concentration (the size of the read-out at that concentration, not a potency): 93.4%
Compound 3: middle estimate off by 8.4 percentage points, on the low side; the range from low to high includes it.
By their numbers in this assay, from the lowest: compound 2; then compounds 3 and 1 (each within the scatter of the next).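

In this assay, 2-fluorophenyl in place of 3-fluorophenyl on the carbonyl carbon of the amide gives a number 10.7 percentage points higher from compound 2 to compound 3 (beyond the scatter). These two compounds hold the same atoms, so this site in the acid series responds to where the fluorine sits on the ring, and not only to whether a fluorophenyl group is present. With 2-fluorophenyl held constant, hydrogen in place of ethyl on an oxygen next to a carbonyl group gives a number 3 percentage points lower from compound 1 to compound 3 (within the scatter), so this pair offers no sign that the ethyl ester and the carboxylic acid read differently here. Nothing measured here explains either step.

Going by these compounds, it stays open whether plain phenyl or cyclohexyl on the same carbonyl carbon would read like 2-fluorophenyl or like 3-fluorophenyl, and whether the fluorine shift would give a similar step on the ethyl ester. On these data alone, each number is also a single inhibition reading at one concentration, so how these compounds compare in potency remains unknown.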